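The source may hold more compounds than are shown below. What is called first, only, known or untested is meant among the compounds shown, and "the series" means these compounds.

Measured so far in a functional assay on cells (Lymphocyte, Homo sapiens), read by trypan blue exclusion, with a stated time of 16 h, tested at 0.1 uM; on this read-out higher numbers stand for a stronger effect at the one concentration tested and lower numbers for a weaker effect:

compound 1, `CCCCCCCCCCCCCCCCc1c(C)c(N(C)C)nc(C)c1O`: 52%
compound 2, `CCCCCCCCCCCCCCCCCCCc1c(C)c(N(C)C)nc(C)c1O`: 20%
compound 3, `CCCCCCCCCCCCCCCCCCCc1nc(N(C)C)c(C)c(C)c1O`: 17%

Compound 1 and compound 2 share a core and differ only in the chain: the change hydrogen in place of propyl on a saturated chain carbon, ten or more bonds along the chain from an aromatic carbon gives the step of a number 32 percentage points higher from compound 2 to compound 1 (beyond the scatter), a large one. Compound 3 has the same atoms as compound 2 joined differently; the difference between the two cores is not broken down here. The values of compound 3 and compound 2 in this assay lie within the scatter of each other, so nothing separates them.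

Compound 4, `CCCCCCCCCCCCCCCCc1nc(N(C)C)c(C)c(C)c1O`, is not yet measured. It differs from compound 3 by hydrogen in place of propyl on a saturated chain carbon, ten or more bonds along the chain from an aromatic carbon, the same change, in the same place, as that from compound 2 to compound 1. Within the data shown here, on the single earlier example, compound 3 to compound 4 is expected to give a number 28 percentage points higher from compound 3 to compound 4 (beyond the scatter) in this assay, because the earlier step of a number 32 percentage points higher from compound 2 to compound 1 (beyond the scatter) was of that kind; with only one precedent the range is kept wide. Compound 4 is thus estimated at 45%, between 25% and 65%.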

Compound 4, a percentage reported as activity, at one concentration (the size of the read-out at that concentration, not a potency): 80%
For compound 4 the middle estimate is 35 percentage points below the measured one; measured number above the stated range.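

In this assay, hydrogen in place of propyl on a saturated chain carbon, ten or more bonds along the chain from an aromatic carbon, gives a number 63 percentage points higher from compound 3 to compound 4 (beyond the scatter), so the direction of the step carries over from one core to the other while its size does not: the same change on two cores in this assay, a number 32 percentage points higher (beyond the scatter) from compound 2 to compound 1 and a number 63 percentage points higher (beyond the scatter) from compound 3 to compound 4, 31 percentage points apart, beyond the scatter of two such steps

A step measured on one of these cores therefore predicts the direction on the other here, but not the size. Two pairs do not show why the size differs or how the change would behave on a third core, and since the read-out comes from one concentration, neither step says anything about potency.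

The compounds shown leave open how the read-out changes with a chain shorter than that of compound 4, or with one of a length between the two shown. They also leave open whether a chain ending in an amine or a carboxylic acid would follow the same course as these plain chains.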